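Aryl substituent swap in a tricyclic CRF receptor series

The compounds below may be only part of what the source reports. "The series", "measured", "known", "first", "only" and "open" are said of these compounds alone.

Measured so far:
- compound 2, `CCCCN(CC)c1cc(C)nc2c1NC(=O)CN2c1ccc(Cl)cc1Br`: 2.5 nM
- compound 3, `CCCCN(CC)c1cc(C)nc2c1NC(=O)CN2c1ccc(Br)cc1C`: 4.4 nM
- compound 1, `CCN(C)c1cc(C)nc2c1NC(=O)CN2c1ccc(C(C)C)cc1Br`: 16.4 nM

In an assay on HEK-293T cells for displacement of a labelled ligand from corticotropin-releasing factor receptor 1 (Homo sapiens), read by scintillation counting, with a stated time of 2 h (a lower number here means a stronger inhibitor, a higher number a weaker inhibitor), compound 2 gives the lowest of the three numbers. Its nearest neighbour is compound 3, reached by a 1.8-fold higher number from compound 2 to compound 3 (0.25 log units; within the scatter); that step carries 4-bromo-2-methylphenyl in place of 2-bromo-4-chlorophenyl on a nitrogen on an aromatic ring in a ring. Among the measured compounds shown here, compound 1 differs from compound 2 in two places and its value stands clearly higher, but no single-change step connects the two, so only the two numbers can be compared.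

Compound 4, `CCCCN(CC)c1cc(C)nc2c1NC(=O)CN2c1ccc(C)cc1Br`, remains to be measured in this assay. Against compound 2 the change is methyl in place of chloro on an aromatic carbon, that is, 2-bromo-4-chlorophenyl to 2-bromo-4-methylphenyl. The only comparable step shown, from compound 2 to compound 3, rearranges the halogen and methyl groups on the same ring and stays within the scatter. A change confined to one substituent on that ring is therefore expected to move the number little; a step of a 1.4-fold higher number from compound 2 to compound 4 (0.15 log units; within the scatter) is estimated, in the direction of a slightly higher number, without confidence that it exceeds the scatter. For compound 4 the expected value is 3.5 nM, with a range from 1.5 nM to 8 nM.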

Compound 4, inhibition constant: 4.4 nM
Compound 4: the middle estimate sits 1.3-fold (0.10 log units) below what was measured; the measured number falls inside the stated range.
By their numbers in this assay, from the lowest: compounds 2, 3 and 4 (each within the scatter of the next); then compound 1.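

On the aromatic carbon meta to a bromo group and para to a large group, methyl in place of chloro gives a 1.8-fold higher number from compound 2 to compound 4 (0.25 log units; within the scatter) in this assay and isolates this one substituent, which the earlier step between compound 2 and compound 3 could not do, as it changed the ring at more than one place. The new comparison of bromo and methyl arrangements gives no change at the digits printed from compound 3 to compound 4 (within the scatter) and shows that 2-bromo-4-methylphenyl and 4-bromo-2-methylphenyl cannot be told apart in this measurement, so chloro at this carbon is not needed for a low number among these compounds. No supporting data accompany these binding numbers to account for either step.

Chloro and methyl are the only groups compared at this carbon, so it remains open whether a methoxy group, a trifluoromethyl group or a nitrile would also stay within the scatter. Compound 1 differs from the others in both the amine chain and the aryl group, which leaves the separate contribution of isopropyl at this carbon unresolved.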